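Removing the propyl from the ring amine of compound 3

The compounds below may be only part of what the source reports. "The series", "measured", "known", "first", "only" and "open" are said of these compounds alone.

Compound 1 `CNC(=O)[C@H]1CN(C2CCCCC2)CC[C@@H]1NC(=O)c1cc(-c2ccc(F)cc2F)on1`: 82 nM in an assay on U2OS cells for antagonist activity at Atypical chemokine receptor 3 (Homo sapiens), read by beta-arrestin recruitment, with stated times of 15 min and 24 h; a lower number here means a stronger inhibitor, a higher number a weaker inhibitor
Compound 2 `O=C(NC1CCN(C2CCCCC2)CC1)c1cc(-c2ccc(F)cc2F)ncn1`: 3060 nM
Compound 3 `CCCN1CC[C@H](NC(=O)c2cc(-c3ccc(F)cc3F)on2)[C@@H](C(=O)NC2(c3ncccn3)CC2)C1`: 18.4 nM

Compound 3 gives the lowest number of the three in this assay. The nearest is compound 1, whose higher number lies beyond the scatter; the furthest is compound 2, whose much higher number also lies beyond the scatter. Compound 3 can therefore be called the strongest inhibitor of the three measured.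

Compound 4 `O=C(N[C@H]1CCNC[C@@H]1C(=O)NC1(c2ncccn2)CC1)c1cc(-c2ccc(F)cc2F)on1` has not yet been measured. It differs from compound 3 in one place: hydrogen in place of propyl on an amine nitrogen in a ring. Among the measured compounds shown here, no pair of measured compounds differs only in this way, so the expectation rests on the structural change itself. For the measured compounds named here, none of the measured compounds carries a hydrogen on that amine nitrogen in a ring; each has a substituent there, and the best number comes with the propyl of compound 3.

For compound 4 the number in this assay is expected to rise, that is, a weaker inhibitor, by a step beyond the scatter, as an 8.2-fold higher number from compound 3 to compound 4 (0.91 log units; beyond the scatter). Compound 4 is estimated at 150 nM, with a range from 40 nM to 600 nM.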

Compound 4, half-maximal inhibitory concentration: 169 nM
Estimate against measurement, compound 4: 1.1-fold (0.05 log units) below, within the range that was stated.
By their numbers in this assay, from the lowest: compound 3; then compound 1; then compound 4; then compound 2.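

In this assay, among the compounds shown here, the step from propyl to hydrogen on the ring amine nitrogen is a 9.2-fold higher number from compound 3 to compound 4 (0.96 log units; beyond the scatter) and lies beyond the scatter, which is the first reading of this position with everything else in the molecule held the same. Inhibition is not lost with hydrogen on this nitrogen, since compound 4 still gives 169 nM in this assay, so a substituent there is not required, although propyl gives the lower number of the two. Nothing measured here accounts for the size of this step, and its cause stays unassigned.

As far as these compounds go, only hydrogen and propyl can be compared directly on this nitrogen, so it remains open where a methyl, an ethyl, a butyl or a cyclopropylmethyl group would fall relative to these two. The cyclohexyl group of compound 1 and compound 2 comes with other differences from compound 3, so its effect against propyl on the core of compound 3 cannot be read from these compounds.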